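The compounds below may be only part of what the source reports. "The series", "measured", "known", "first", "only" and "open" are said of these compounds alone.

Among the compounds with values here, in an ADME assay on L02 cells (Homo sapiens) for cytotoxicity, read by MTT assay, with a stated time of 24 h (a higher number here means a weaker inhibitor, a lower number a stronger inhibitor), compound 2 (`CN1C/C(=C\c2ccc(C#N)cc2)C(=O)/C(=C/c2ccccc2F)C1`) gives 11000 nM, the lower of the two numbers measured so far. Compound 1 (`CN1C/C(=C\c2ccc(C(C)(C)C)cc2)C(=O)/C(=C/c2ccccc2F)C1`) gives 25800 nM. Compound 3 (`CN1C/C(=C\c2ccc(C#N)cc2)C(=O)/C(=C/c2ccc(Cl)cc2Cl)C1`) differs from compound 2 in one group: 2,4-dichlorophenyl in place of 2-fluorophenyl on a double-bonded chain carbon bound to a double-bonded ring carbon. Within the data shown here, the only measured step, a 2.3-fold lower number from compound 1 to compound 2 (0.37 log units; beyond the scatter), was modest and replaced tert-butyl with cyano on an aromatic carbon, so it involves a different group and gives no direction for this change. No step beyond the scatter is therefore expected in this assay, and the estimated step is a 1.1-fold lower number from compound 2 to compound 3 (0.04 log units; within the scatter). For compound 3 the estimated value is 10000 nM, with an expected range from 4000 nM to 25000 nM.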

Compound 3, half-maximal inhibitory concentration: 10800 nM
Beside the measured number, compound 3's estimate is 1.1-fold (0.03 log units) below it; measured number inside the range.
By their numbers in this assay, from the lowest: compounds 3 and 2 (each within the scatter of the next); then compound 1.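

Putting 2,4-dichlorophenyl in place of 2-fluorophenyl on a double-bonded chain carbon bound to a double-bonded ring carbon gives a 1.0-fold lower number from compound 2 to compound 3 (0.01 log units; within the scatter) in this assay. Within the data shown here, the only earlier step exchanged tert-butyl for cyano, so this is the first sign that this position can take a second chlorine-bearing change of aryl group without the number moving beyond the scatter. Nothing measured here offers a reason for this result. Still open, on these data alone, is whether an amine or a carboxylic acid on this phenyl ring would shift the number. Also open, as far as these compounds go, is whether 2,4-dichlorophenyl would give the same result with tert-butyl in place of cyano.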